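The source may hold more compounds than are shown below. What is called first, only, known or untested is meant among the compounds shown, and "the series" means these compounds.

Compound 1, `Cc1n[nH]c(C(=O)O)c1Cc1cccc(-c2cccc(F)c2)c1`, gives 50% in an assay on isolated protein for inhibition of 2-Hydroxyacid oxidase 2 (Homo sapiens), tested at 10 uM; a lower number here means a weaker effect, a higher number a stronger effect of the compound at the concentration tested. Among the three compounds measured there, compound 1 stands highest: compound 2, `Cc1n[nH]c(C(=O)O)c1Cc1ccc(C#N)cc1`, gives 6% in this assay, and compound 3, `Cc1c(Cc2cccc(-c3ccc(F)cc3)c2)c(C(=O)O)nn1C`, gives 4%. Both lie below compound 1 by margins well beyond the usual scatter, compound 2 being the nearer and compound 3 the further of the two.

Compound 4, `Cc1n[nH]c(C(=O)O)c1Cc1cccc(C#N)c1`, is the next compound to be measured in this assay. It differs from compound 1 in one place: cyano in place of 3-fluorophenyl on an aromatic carbon. Within the data shown here, no pair of measured compounds differing in exactly one place is available, so the size of this step cannot be read from a measured step. What can be said is that compound 2 also carries a cyano group on a six-membered aromatic ring of carbon only, and compound 2 gives 6% in this assay, whereas compound 1, carrying the 3-fluorophenyl group, gives 50%. On that basis the step is expected to be downward and beyond the scatter, as a number 40 percentage points lower from compound 1 to compound 4 (beyond the scatter) expresses. Compound 4 is expected to give 10% in this assay, within a range from 0% to 30%.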

Compound 4, a percentage reported as inhibition, at one concentration (the size of the read-out at that concentration, not a potency): 19%
Estimate against measurement, compound 4: 9 percentage points below, within the range that was stated.
By their numbers in this assay, from the lowest: compounds 3 and 2 (each within the scatter of the next); then compound 4; then compound 1.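

Among these compounds, exchanging 3-fluorophenyl for cyano on an aromatic carbon gives, in this assay, a number 31 percentage points lower from compound 1 to compound 4 (beyond the scatter), the first step between these compounds that can be read directly. It shows that the group at this position is not indifferent: the 3-fluorophenyl group, with its six-membered aromatic ring of carbon only, goes with the higher read-out at the concentration tested, and compound 4, with cyano, gives 19%. Nothing measured here accounts for the size of this step.

This single step cannot separate the contribution of the ring from that of the fluorine, since both leave together. On these data alone, an unsubstituted phenyl ring at this carbon would bear on that question, and how a methoxy group, an amine or a longer alkyl chain would fare there remains open.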